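The source may report more compounds than this note shows. Statements on the series, on what has been measured and on what is new or still open speak of the compounds shown alone.

Three compounds share one core and differ in what hangs from the sulfur attached to that core. Compound 1 `Nc1cc(S(=O)(=O)c2ccccc2)c([N+](=O)[O-])c2cccnc12` carries a phenyl on a sulfonyl sulfur, and in an assay for binding affinity to Neuropeptide Y receptor type 1 (Homo sapiens), read by radioligand binding (on this read-out higher numbers stand for weaker inhibition and lower numbers for stronger inhibition), compound 1 gives 297 nM. Compound 2 `CS(=O)(=O)c1cc(N)c2ncccc2c1[N+](=O)[O-]` carries a methyl on the sulfonyl sulfur instead. In this assay the result for compound 2 is a limit of the assay, > 10000 nM. Compound 3 `Nc1ccc(Sc2cc(N)c3ncccc3c2[N+](=O)[O-])cc1` carries an aminophenyl on a sulfur without oxygens. For compound 3 the result is also a limit of the assay, > 10000 nM. Compound 2 therefore stands at the weak end of what has been measured, at the limit of > 10000 nM in this assay, at which 2 of the 3 values shown sit. Going by the values given here, the one measured step that bears on the question is the change of phenyl to methyl, which gave an at least 33-fold higher number from compound 1 to compound 2 (1.52 log units; beyond the scatter).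

Compound 4 `COc1ccc(S(=O)(=O)c2cc(N)c3ncccc3c2[N+](=O)[O-])cc1` has not been measured. Its change from compound 2 is 4-methoxyphenyl in place of methyl on a sulfonyl sulfur, which largely undoes the step that weakened compound 1 into compound 2 and adds a methoxy on the ring. A large step toward stronger binding is therefore expected, of about an at least 33-fold lower number from compound 2 to compound 4 (1.52 log units; beyond the scatter). Compound 4 is expected to give 300 nM, with a range from 60 nM to 2000 nM.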

Compound 4, inhibition constant: 1140 nM
The estimate for compound 4 lay 3.8-fold (0.58 log units) below the measured number; the measured number falls inside the stated range.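

Placing an aromatic ring on the sulfonyl sulfur gives a measurable number again: in this assay, 4-methoxyphenyl in place of methyl on a sulfonyl sulfur gives an at least 8.7-fold lower number from compound 2 to compound 4 (0.94 log units; beyond the scatter), so compound 1 is no longer the only compound here with a number that is not a limit. The result for compound 2 is a limit of the assay, so this step gives only a minimum size: the limit of > 10000 nM in this assay, at which 2 of the 4 values shown sit. What the ring carries also matters, as methoxy in place of hydrogen on an aromatic carbon gives a 3.8-fold higher number from compound 1 to compound 4 (0.58 log units; beyond the scatter), so a ring on the sulfonyl sulfur is compatible with binding, but a single added group still shifts the number.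

With methoxy as the only group shown on that ring, it remains open whether a fluorine, a methyl or a carboxylic acid in the same place would shift the number in the same direction. From the compounds shown here alone, it is also open whether the sulfonyl sulfur needs an aromatic ring at all, or whether a longer chain such as butyl or a saturated ring such as cyclohexyl would give a measurable number there too.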